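Pyridin-4-yl for 4-fluorophenyl: the step to compound 4

The source may report more compounds than this note shows. Statements on the series, on what has been measured and on what is new or still open speak of the compounds shown alone.

Measured so far:
compound 1 `NC1(CN(C(=O)[C@@H]2C[C@H]2c2ccccc2)c2ccc(-c3ccccc3)cc2)CCCC1` gives 0.57 nM
compound 2 `CC(C)CCNCCN(C(=O)[C@@H]1C[C@H]1c1ccccc1)c1ccc(-c2ccccc2)cc1` gives 5.1 nM
compound 3 `CC[C@H](C)[C@H](N)CN(C(=O)[C@@H]1C[C@H]1c1ccc(F)cc1)c1ccc(-c2ccccc2)cc1` gives 600 nM

All three numbers come from a functional assay for agonist activity at G protein-coupled receptor 88 (Homo sapiens), read by HTRF and cAMP accumulation; a lower number here means that less compound is needed, a higher number that more compound is needed for the effect. Compound 3 has the highest number of the three; compound 2 stands nearer to it and compound 1 furthest, each of the two gaps beyond the scatter. Among the measured compounds shown here, the only step between compounds that differ in one place is an 8.9-fold higher number from compound 1 to compound 2 (0.95 log units; beyond the scatter), which concerns the group on the saturated chain carbon bound to the amide-type nitrogen and leaves the aryl ring on the three-membered ring untouched.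

Compound 4 `CC[C@H](C)[C@H](N)CN(C(=O)[C@@H]1C[C@H]1c1ccncc1)c1ccc(-c2ccccc2)cc1` differs from compound 3 by pyridin-4-yl in place of 4-fluorophenyl on a saturated ring carbon. For the measured compounds named here, no measured pair bears on this change: nothing in the set alters the ring attached to the three-membered non-aromatic ring of carbon only, and compound 3 is the only compound carrying the 4-fluorophenyl group at all. Going by the values given here, the change keeps the ring size and adds one hydrogen-bond acceptor while removing the fluorine, so with no precedent the expectation is a step of no change at the digits printed from compound 3 to compound 4 (within the scatter), within the scatter, with a wide range in either direction. Compound 4 is therefore estimated at 600 nM, expected between 200 nM and 1800 nM in this assay.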

Compound 4, half-maximal effective concentration: 1500 nM
For compound 4 the middle estimate is 2.5-fold (0.40 log units) below the measured one; the range from low to high includes it.
By their numbers in this assay, from the lowest: compound 1; then compound 2; then compound 3; then compound 4.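

Working notes on the aryl position. In this assay, pyridin-4-yl in place of 4-fluorophenyl on the saturated ring carbon of the three-membered ring gives a 2.5-fold higher number from compound 3 to compound 4 (0.40 log units; beyond the scatter), so this position responds to a change of ring even when the ring size stays the same. Among the compounds shown here, the earlier step concerned only the group on the saturated chain carbon, so this is the first reading at the aryl position, and it shows that the hydrogen-bond acceptor entering with the ring nitrogen brings no gain with the side chain of compound 3. Nothing at hand accounts for the direction or size of this step.

As far as these compounds go, the ring nitrogen enters and the fluorine leaves in the same step, so their shares remain open, and pyridin-3-yl or 4-chlorophenyl at this place would give further readings on ring nitrogen position and ring substituent. Also open, from the compounds shown here alone, is whether the step carries over to the 1-aminocyclopentyl group of compound 1 or the (isopentylamino)methyl group of compound 2, where the numbers in this assay are far lower.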